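The compounds below may be only part of what the source reports. "The series", "measured", "known", "first", "only" and "open" are said of these compounds alone.

Measured so far in an ADME assay on Vero cells (Chlorocebus sabaeus) for cytotoxicity, read by resazurin assay, with a stated time of 72 h; on this read-out higher numbers stand for lower toxicity in this test and lower numbers for higher toxicity in this test:

Compound 1 `CC(C)(C)c1ccc(C(=O)/C=C/c2ccc([N+](=O)[O-])o2)cc1`: > 100000 nM
Compound 2 `O=C(/C=C/c1ccc([N+](=O)[O-])o1)c1ccc(Br)cc1`: > 100000 nM
Compound 3 `O=C(/C=C/c1ccc([N+](=O)[O-])o1)c1cccc(Br)c1`: 68800 nM

Compound 1 gives no number in this assay, only a limit, > 100000 nM. Compound 2 likewise returns only a limit, > 100000 nM. Compound 3 gives a number, 68800 nM. Within the data shown here, the single step between compounds that differ in one place, a step that the two limits leave unreadable from compound 1 to compound 2, cannot be sized because both of its values sit at the limit of > 100000 nM in this assay, at which 2 of the 3 values shown sit. Compound 2 therefore stands at the upper limit of the assay, with no readable step leading to or from it.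

Compound 4 `O=C(/C=C/c1ccc([N+](=O)[O-])o1)c1ccc(I)cc1` differs from compound 2 by iodo in place of bromo on an aromatic carbon. Among the measured compounds shown here, no measured step involves this change, and the one step measured is unreadable, so there is no evidence for any shift beyond the usual scatter. Compound 4 is expected to remain where compound 2 stands, the step of a number no higher from compound 2 to compound 4 (the limit leaves the size open) being no more than scatter. The estimate for compound 4 in this assay is 100000 nM, expected between 50000 nM and 200000 nM, most likely reported again as a limit.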

Compound 4, half-maximal cytotoxic concentration: > 100000 nM
Compound 4: a limit, no number (the forecaster's own chance of this, stated with the estimate: 65%); the middle value sits exactly at the limit.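

In this assay compound 4 gives only a limit, > 100000 nM. No step among compound 1, compound 2 and compound 4 can be read, all three sitting at the same limit: the limit of > 100000 nM in this assay, at which 3 of the 4 values shown sit.

From the compounds shown here alone, whether tert-butyl, bromo and iodo on that aromatic carbon differ at all on this read-out stays open.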